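A few compounds are considered here, and "the series" means these few. Any claim that something is new, unique, unknown or untested is made for them only; others in the source may bear on it.

Two related compounds have been measured so far in a physicochemical assay for lipophilicity; a higher number here means a more lipophilic compound, a lower number a more polar compound. Compound 1 `C[C@H]1CC[C@@H]2[C@@H](OC(=O)[C@]23CC(c2ccc(Cl)cc2)=NO3)[C@]2(C)C(=O)C=C[C@@]12O` gives 2.09, and compound 2 `C[C@H]1CC[C@@H]2[C@@H](OC(=O)[C@]23CC(c2ccc(Br)cc2)N(c2ccccc2)O3)[C@]2(C)C(=O)C=C[C@@]12O` gives 4, the higher of the two numbers, with a gap well beyond the usual scatter of such measurements. Compound 3 `C[C@H]1CC[C@@H]2[C@@H](OC(=O)[C@]23CC(c2c(Cl)cccc2Cl)N(c2ccccc2)O3)[C@]2(C)C(=O)C=C[C@@]12O` has not been measured yet. It matches compound 2 except for one group: 2,6-dichlorophenyl stands in place of 4-bromophenyl on a saturated ring carbon (2,6-dichlorophenyl in place of 4-bromophenyl on a saturated ring carbon). Within the data shown here, no measured pair shows what this swap does, so the expectation rests on the swap itself and on compound 2 at 4. Each group is one six-membered aromatic ring of carbon only, with no hydrogen-bond donors or acceptors and no net charge. The expected step is a number 0.10 log units higher from compound 2 to compound 3 (within the scatter), which is nothing beyond the scatter. Compound 3 is estimated at 4.1, with an expected range of 3.6 to 4.6.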

Compound 3, partition coefficient: 4.45
For compound 3 the middle estimate is 0.35 log units below the measured one; measured number inside the range.
By their numbers in this assay, from the lowest: compound 1; then compound 2; then compound 3.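

This position, on a saturated ring carbon next to the ring nitrogen, now has its first readable step: in this assay the change to 2,6-dichlorophenyl from 4-bromophenyl gives a number 0.45 log units higher from compound 2 to compound 3 (beyond the scatter) and so registers in this measurement. That holds even though the two groups match in being one six-membered aromatic ring of carbon only, with no hydrogen-bond donors or acceptors and no net charge, so those shared counts do not settle the number here. Nothing measured alongside this result accounts for the step, and its origin stays unassigned.

This single swap changes both the halogen and its place on the ring, so the two changes cannot be told apart. On these data alone, how a 4-chlorophenyl group, or a pyridine ring or a ring carrying an amine, would read at this carbon remains open.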